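A few compounds are considered here, and "the series" means these few. Any claim that something is new, unique, unknown or untested is made for them only; others in the source may bear on it.

Measured in a functional assay on Jurkat cells (Homo sapiens) for cytotoxicity, with a stated time of 72 h; a lower number here means that less compound is needed, a higher number that more compound is needed for the effect:
- Compound 1 `C=C[C@@](C)(/C=C/c1ccc(O)cc1)CCC=O`: > 49000 nM
- Compound 2 `C=C[C@@](C)(/C=C/c1ccc(O)cc1)CCCO`: > 49000 nM
- Compound 3 `C=C[C@@](C)(/C=C/c1ccc(O)cc1)CC/C=C/C(=O)c1ccccc1`: > 49000 nM

Each of these entries is a limit of the assay and not a number. Compound 3 therefore stands only at a limit, > 49000 nM. The whole series sits there: the limit of > 49000 nM in this assay, at which 3 of the 3 values shown sit.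

Compound 4 `C=C[C@@](C)(/C=C/c1ccc(O)cc1)CC/C=C/C#N` carries cyano in place of benzoyl on a double-bonded chain carbon bound to a double-bonded chain carbon.

For the measured compounds named here, the one measured step, a step that the two limits leave unreadable from compound 1 to compound 2, gives no usable size, and no measured step covers this change. Going by the values given here, no step of known size or direction can therefore be expected in this assay.

With compound 3 at > 49000 nM, the expectation is that compound 4 also reports only a limit. The expected step is a step that the limit leaves unreadable from compound 3 to compound 4. Compound 4 is estimated at 60000 nM, with an expected range of 30000 nM to 120000 nM.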

Compound 4, half-maximal effective concentration: > 49000 nM
Compound 4: a limit, no number; the forecaster's own chance of this, stated with the estimate: 85%; the middle value does not contradict the limit.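

Compound 4 gives > 49000 nM in this assay, which is a limit and not a number, so the steps to it from compound 1, compound 2 and compound 3 cannot be read. How these four compounds rank against one another stays open, because all of them stop at the same point: the limit of > 49000 nM in this assay, at which 4 of the 4 values shown sit.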